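Swapping Chloro for Fluoro on a Fatty Acid Receptor Agonist

This account rests on a few compounds, and the source may have more. Where it says the series, first, only, none or still open, it means among the compounds named here.

Four compounds share an acid-bearing chain attached to a core of two linked rings. Compound 1 `O=C(O)CCCOc1ccc(-c2cc(Oc3cccc(F)c3)ccc2Cl)cc1` and compound 2 `O=C(O)CCCOc1ccc(-c2cc(Oc3cccc(F)c3)ccc2F)cc1` differ in one place: fluoro in place of chloro on an aromatic carbon. In a functional assay on isolated protein for agonist activity at Free fatty acid receptor 1 (Homo sapiens), read by HTRF and inositol phosphate accumulation, with a stated time of 60 min (a higher number here means that more compound is needed for the effect, a lower number that less compound is needed), compound 1 gives 3350 nM, while compound 2 gives 9460 nM; the step is a 2.8-fold higher number from compound 1 to compound 2 (0.45 log units; beyond the scatter). Compound 3 `Cc1cc(-c2cc(OC(F)(F)F)ccc2Cl)ccc1OCCCC(=O)O` carries a different core, and how its core differs from that of compound 1 is not broken down here. In this assay compound 3 gives 6720 nM, which lies within the scatter of compound 2. Compound 4 `Cc1cc(-c2cc(OC(F)(F)F)ccc2F)ccc1OCCCC(=O)O` has not yet been measured; it differs from compound 3 by fluoro in place of chloro on an aromatic carbon. The surroundings of this change match the earlier one except that the group para to it is a trifluoromethoxy group rather than a 3-fluorophenoxy group, so this is the same kind of change, not the same change. The expected step is a 2.5-fold higher number from compound 3 to compound 4 (0.40 log units; beyond the scatter), resting on a 2.8-fold higher number from compound 1 to compound 2 (0.45 log units; beyond the scatter). Compound 4 is therefore expected to give about 17000 nM, estimated between 7000 nM and 40000 nM.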

Compound 4, half-maximal effective concentration: 9260 nM
Beside the measured number, compound 4's estimate is 1.8-fold (0.26 log units) above it; the range from low to high includes it.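

On the core of compound 3, fluoro in place of chloro gives a 1.4-fold higher number from compound 3 to compound 4 (0.14 log units; within the scatter) in this assay, a step too small to be told apart from the ordinary spread of repeat measurements. Set beside the same swap on the core of compound 1, the new step shows no real disagreement between the two cores: the same change on two cores in this assay, a 2.8-fold higher number (0.45 log units; beyond the scatter) from compound 1 to compound 2 and a 1.4-fold higher number (0.14 log units; within the scatter) from compound 3 to compound 4, 2.0-fold (0.31 log units) apart, within the scatter of two such steps. Among the compounds shown here, this fits the idea that the swap acts in a similar way on both cores, but two pairs cannot establish that, and they do not fix a single size for the step, as only the step on the core of compound 1 stands clear of the scatter.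

The compounds shown leave open how other groups at this aromatic carbon, such as bromo, methyl or nitrile, would compare with chloro and fluoro. They also leave open whether the swap would behave alike on a core with a longer acid chain or with an amine in the chain.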